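A Bromo-Hydroxy Swap on the Weakest Compound

A few compounds are considered here, and "the series" means these few. Any claim that something is new, unique, unknown or untested is made for them only; others in the source may bear on it.

In a functional assay on PC-3 cells (Homo sapiens) for antiproliferative activity, read by MTT assay, with a stated time of 72 h (on this read-out lower numbers stand for stronger inhibition and higher numbers for weaker inhibition), compound 1 `O=C(N/N=C/c1ccccc1)Nc1ccc(Oc2ccnc3[nH]ccc23)c(F)c1` gives 7940 nM, compound 2 `O=C(N/N=C/c1cccc(Br)c1)Nc1ccc(Oc2ccnc3[nH]ccc23)c(F)c1` gives 4020 nM, and compound 3 `O=C(N/N=C/c1ccc(Cl)c(Cl)c1)Nc1ccc(Oc2ccnc3[nH]ccc23)c(F)c1` gives 14100 nM. Compound 3 holds the highest of these three numbers. The measured steps that bear on it are a 1.8-fold higher number from compound 1 to compound 3 (0.25 log units; within the scatter) and the modest 3.5-fold higher number from compound 2 to compound 3 (0.54 log units; beyond the scatter). Compound 4 `O=C(N/N=C/c1ccc(O)c(Br)c1)Nc1ccc(Oc2ccnc3[nH]ccc23)c(F)c1` has 3-bromo-4-hydroxyphenyl in place of 3,4-dichlorophenyl on a carbon with a double bond to nitrogen. Going by the values given here, compound 2 also carries a bromo group, at 4020 nM, but no measured compound carries a hydroxy group, so only a modest move towards a lower number is expected. The expected change is a 2.2-fold lower number from compound 3 to compound 4 (0.34 log units; beyond the scatter). For compound 4 the estimate is 6500 nM, with an expected range of 2500 nM to 16000 nM.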

Compound 4, half-maximal inhibitory concentration: 28600 nM
Compound 4: the middle estimate sits 4.4-fold (0.64 log units) below what was measured; measured number outside the range, above it.
By their numbers in this assay, from the lowest: compounds 2, 1 and 3 (each within the scatter of the next, the first and the last beyond it); then compound 4.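

Adding a hydroxy group to the ring that already carries bromo brings a 7.1-fold higher number from compound 2 to compound 4 (0.85 log units; beyond the scatter) in this assay and is the largest step shown. The 3-bromo-4-hydroxyphenyl ring also gives a 2.0-fold higher number from compound 3 to compound 4 (0.31 log units; beyond the scatter) and a 3.6-fold higher number from compound 1 to compound 4 (0.56 log units; beyond the scatter) and so has the highest number of the four rings on the carbon with a double bond to nitrogen. No measurement here accounts for this rise. Going by these compounds, what remains open is how a hydroxy group fares on a ring without bromo. On these data alone, it is also open whether a methoxy group or an amine in its place would raise the number too.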